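This account rests on a few compounds, and the source may have more. Where it says the series, first, only, none or still open, it means among the compounds named here.

Compound 1 `CCn1c(C(=O)N[C@@H](CC(=O)OC)C(=O)OC)ccc1C(CC)(CC)c1ccc(OCS(=O)(=O)c2ccccc2)c(C)c1` is the starting point of this account. In a functional assay on MCF7 cells (Homo sapiens) for antiproliferative activity, read by MTT assay, with a stated time of 24 h (a higher number here means a weaker inhibitor, a lower number a stronger inhibitor), compound 1 reaches only the limit of the assay, > 50000 nM, so no number is known for it; it sits at the limit (the limit of > 50000 nM in this assay, at which 1 of the 3 values shown sits), shared by none of the other two values. Compound 2 `CCn1c(C(=O)N[C@H](CO)CCCO)ccc1C(CC)(CC)c1ccc(OCS(=O)(=O)c2ccccc2)c(C)c1` gives 31400 nM in this assay, a change of an at least 1.5-fold lower number from compound 1 to compound 2 (0.20 log units; that floor lies within the scatter). Compound 3 `CCn1c(C(=O)N[C@H](C(=O)O)C(C)C)ccc1C(CC)(CC)c1ccc(OCS(=O)(=O)c2ccccc2)c(C)c1` gives 24500 nM in this assay, a change of an at least 2.0-fold lower number from compound 1 to compound 3 (0.30 log units; that floor lies within the scatter), while the step of a 1.3-fold lower number from compound 2 to compound 3 (0.11 log units; within the scatter) lies within the scatter.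

Compound 4 `CCn1c(C(=O)N[C@@H](C(=O)O)C(C)C)ccc1C(CC)(CC)c1ccc(OCS(=O)(=O)c2ccccc2)c(C)c1` has not been measured in this assay. It differs from compound 1 by 1-carboxy-2-methylpropyl in place of 1,2-bis(methoxycarbonyl)ethyl on an amide-type nitrogen. The step from compound 1 to compound 3 carries the same group into the same place, and its size of an at least 2.0-fold lower number from compound 1 to compound 3 (0.30 log units; that floor lies within the scatter) is only a floor, since compound 1 is a limit. Compound 3, which carries the same 1-carboxy-2-methylpropyl group, gives 24500 nM, and compound 4 is therefore expected near that value. Compound 4 is estimated at 30000 nM, within 12000 nM to 60000 nM, which is expected to mean a step of an at least 1.6-fold lower number from compound 1 to compound 4 (0.22 log units; that floor lies within the scatter).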

Compound 4, half-maximal inhibitory concentration: 44700 nM
The estimate for compound 4 lay 1.5-fold (0.17 log units) below the measured number; low and high end bracket the measured number.
By their numbers in this assay, from the lowest: compounds 3, 2 and 4 (each within the scatter of the next). At a limit, above all of these: compound 1.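

Inverting the saturated chain carbon, drawn S in compound 3 and R in compound 4, gives a 1.8-fold higher number from compound 3 to compound 4 (0.26 log units; within the scatter) in this assay, so no effect of configuration at this position can be told from the scatter: the fact that compounds 3 and 4 differ only in the configuration as drawn. Compound 1 stands at a limit, so the step of an at least 1.1-fold lower number from compound 1 to compound 4 (0.04 log units; that floor lies within the scatter) is only a floor and does not show how far the change from 1,2-bis(methoxycarbonyl)ethyl to 1-carboxy-2-methylpropyl moves the number: the limit of > 50000 nM in this assay, at which 1 of the 4 values shown sits. The step of a 1.4-fold higher number from compound 2 to compound 4 (0.15 log units; within the scatter) adds that the group of compound 2 and the group of compound 4 on the amide-type nitrogen cannot be told apart here.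

The compounds shown leave open whether an amine or a longer carbon chain on this nitrogen would move the number beyond the scatter. They also leave open what a methyl ester in place of the carboxylic acid of 1-carboxy-2-methylpropyl would give.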